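This account rests on a few compounds, and the source may have more. Where it says the series, first, only, none or still open, it means among the compounds named here.

In a functional assay on MCF7 cells (Homo sapiens) for antiproliferative activity, read by MTT assay, with a stated time of 48 h (on this read-out higher numbers stand for weaker inhibition and lower numbers for stronger inhibition), compound 1 (`O=c1cc(-n2cc(CNc3ccccc3)nn2)c2cc(Br)ccc2o1`) reads > 50000 nM, which is a limit of the assay and not a number. Compound 2 (`O=c1cc(-n2cc(CSc3ccccc3)nn2)c2cc(Br)ccc2o1`), with phenylsulfanyl in place of anilino on the same chain carbon, gives 36800 nM in this assay. Going by the values given here, this is the only measured step at that carbon: an at least 1.3-fold lower number from compound 1 to compound 2 (0.13 log units; that floor lies within the scatter). It is a floor only because of the limit of > 50000 nM in this assay, at which 1 of the 2 values shown sits. Compound 3 (`O=c1cc(-n2cc(COc3ccccc3O)nn2)c2cc(Br)ccc2o1`) instead carries 2-hydroxyphenoxy in place of anilino on a saturated chain carbon bound to an aromatic carbon. Given the small step of an at least 1.3-fold lower number from compound 1 to compound 2 (0.13 log units; that floor lies within the scatter), a similarly modest shift toward a lower number is expected in this assay, with no clear move beyond the scatter. The expected step is an at least 1.5-fold lower number from compound 1 to compound 3 (0.18 log units; that floor lies within the scatter). For compound 3 the estimate is 33000 nM, with an expected range of 13000 nM to 60000 nM.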

Compound 3, half-maximal inhibitory concentration: 24800 nM
Compound 3: middle estimate off by 1.3-fold (0.12 log units), on the high side; low and high end bracket the measured number.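

In this assay the change to 2-hydroxyphenoxy on this saturated chain carbon gives an at least 2.0-fold lower number from compound 1 to compound 3 (0.30 log units; that floor lies within the scatter) and that size is only a floor: the limit of > 50000 nM in this assay, at which 1 of the 3 values shown sits. Compound 2 and compound 3 both carry numbers, and the exchange of phenylsulfanyl for 2-hydroxyphenoxy gives a 1.5-fold lower number from compound 2 to compound 3 (0.17 log units; within the scatter) so these two groups are not separated on this read-out. Going by these compounds alone, at this carbon, no printed step yet lies beyond the scatter, although the floors leave the true size of the steps from compound 1 unsettled.

As far as these compounds go, it remains open whether the hydroxy group of 2-hydroxyphenoxy contributes anything, which a plain phenoxy group at the same carbon would test. A piperidine or a carboxylic acid there would show whether this position tolerates a quite different group.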